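Vinyl for prop-1-en-1-yl on a carbonyl carbon

The source may report more compounds than this note shows. Statements on the series, on what has been measured and on what is new or still open speak of the compounds shown alone.

compound 1 `O=C(CCl)N1CCCC(n2nc(-c3ccc(Oc4ccccc4)cc3)cc2CO)C1`: 7800 nM
compound 2 `C/C=C/C(=O)N1CCCC(n2nc(-c3ccc(Oc4ccccc4)cc3)cc2CO)C1`: > 60000 nM

In a functional assay on JeKo-1 cells (Homo sapiens) for inhibition, read by luminescence and CellTiter-Glo, with a stated time of 72 h (on this read-out lower numbers stand for stronger inhibition and higher numbers for weaker inhibition), the two measured compounds sit far apart. Compound 2 stands at the limit of > 60000 nM in this assay, at which 1 of the 2 values shown sits. From the compounds shown here alone, its value is a limit and not a number, so its true position is unknown. Compound 3 `C=CC(=O)N1CCCC(n2nc(-c3ccc(Oc4ccccc4)cc3)cc2CO)C1` has not yet been measured. It differs from compound 2 by one change, (vinyl in place of prop-1-en-1-yl on a carbonyl carbon), that is, vinyl in place of prop-1-en-1-yl on a carbonyl carbon.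

For the measured compounds named here, only one measured step bears on this change, and it alters the same group on the same carbonyl carbon. This is an at least 7.6-fold higher number from compound 1 to compound 2 (0.88 log units; beyond the scatter), which lies beyond the scatter and gives only a minimum size. Going by the values given here, it shows that this assay responds to what sits on this carbon, although no vinyl compound has yet been tested. A move towards stronger inhibition is therefore expected, of moderate but uncertain size. The expected change is an at least 4.0-fold lower number from compound 2 to compound 3 (0.60 log units; beyond the scatter). For compound 3 the estimated value is 15000 nM, with an expected range from 4000 nM to 50000 nM.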

Compound 3, half-maximal inhibitory concentration: 11900 nM
Compound 3: the middle estimate sits 1.3-fold (0.10 log units) above what was measured; the measured number falls inside the stated range.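

In this assay, vinyl in place of prop-1-en-1-yl on the carbonyl carbon gives an at least 5.0-fold lower number from compound 2 to compound 3 (0.70 log units; beyond the scatter), a step of minimum size only, and shows that the extra carbon of prop-1-en-1-yl matters here even though both groups carry a double bond outside aromatic rings. For the compounds shown here, compound 2 is the only compound of the three that stands at a limit and not at a number: the limit of > 60000 nM in this assay, at which 1 of the 3 values shown sits. Vinyl in place of chloromethyl on the same carbon gives a 1.5-fold higher number from compound 1 to compound 3 (0.18 log units; within the scatter), so these two groups cannot be told apart in this assay, and among the three groups shown only prop-1-en-1-yl stands out.

How large the difference between prop-1-en-1-yl and vinyl truly is stays open, since one end of that step is a limit, and the data give no reason for it. Also open, from the compounds shown here alone, is whether a longer chain ending in an amine, or a butynyl group, on this carbonyl carbon would stay level with compound 1 and compound 3, move to stronger inhibition, or lose inhibition as prop-1-en-1-yl does.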